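Side-chain aryl swaps on the shared core: microsomal half-life

The compounds below may be only part of what the source reports. "The series", "measured", "known", "first", "only" and "open" are said of these compounds alone.

compound 1 `COc1ccc(CCOc2ccc(-c3c(C)nc(C)c([C@H](OC(C)(C)C)C(=O)O)c3N3CCC(C)(C)CC3)cc2)cc1` — > 2 h
compound 2 `Cc1cc(CCOc2ccc(-c3c(C)nc(C)c([C@H](OC(C)(C)C)C(=O)O)c3N3CCC(C)(C)CC3)cc2)ccc1F` — > 2 h
compound 3 `Cc1nc(C)c([C@H](OC(C)(C)C)C(=O)O)c(N2CCC(C)(C)CC2)c1-c1ccc(OCCCc2ccc(F)cc2)cc1` — > 2 h

In an ADME assay on microsomes from liver (Rattus norvegicus) for metabolic stability, read by LC-MS, tested at 0.5 uM (on this read-out higher numbers stand for a longer-lived compound and lower numbers for a shorter-lived compound), compound 3 gives > 2 h, which is a limit of the assay and not a number. The same holds for every value shown here, (the limit of > 2 h in this assay, at which 3 of the 3 values shown sit), so compound 3 cannot be placed relative to compound 1 or compound 2. The steps a step that the two limits leave unreadable from compound 1 to compound 3 and a step that the two limits leave unreadable from compound 2 to compound 3 are therefore unreadable, as is a step that the two limits leave unreadable from compound 1 to compound 2.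

Compound 4 `Cc1nc(C)c([C@H](OC(C)(C)C)C(=O)O)c(N2CCC(C)(C)CC2)c1-c1ccc(OCCc2ccccn2)cc1` carries the change (pyridin-2-yl in place of 4-fluorobenzyl on a saturated chain carbon, two bonds along the chain from an oxygen on an aromatic ring). Within the data shown here, no measured step bears readably on this swap, so the size of the step cannot be drawn from the series; the expectation is simply that compound 4 stays near compound 3, with the estimated step that the limit leaves unreadable from compound 3 to compound 4. For compound 4 in this assay the estimate is 2.5 h, in the range 1 h to 6 h.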

Compound 4, half-life: 1.02 h
For compound 4 the middle estimate is 2.5-fold (0.39 log units) above the measured one; the measured number falls inside the stated range.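

Pyridin-2-yl at this position gives an at least 1.9-fold lower number from compound 3 to compound 4 (0.29 log units; that floor lies within the scatter), an at least 1.9-fold lower number from compound 2 to compound 4 (0.29 log units; that floor lies within the scatter) and an at least 1.9-fold lower number from compound 1 to compound 4 (0.29 log units; that floor lies within the scatter) in this assay. Going by these compounds, these steps are floors, so their full size stays unknown. Compound 4 is the only compound here whose half-life is a number and not a limit: the limit of > 2 h in this assay, at which 3 of the 4 values shown sit.

The steps among compound 1, compound 2 and compound 3 cannot be read. Open, on these data alone, is whether a pyridin-3-yl, a pyridin-4-yl or an unsubstituted phenyl on the same chain would also give a number rather than a limit.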